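Notes on a thiazole-amide series: moving the bromine

The source may report more compounds than this note shows. Statements on the series, on what has been measured and on what is new or still open speak of the compounds shown alone.

Measured so far:
compound 1 `CC(C)(C)c1ccc(NC(=O)c2csc(Cc3c(Cl)cccc3Cl)n2)cc1` — 570 nM
compound 2 `O=C(Nc1ccc(Br)cc1)c1csc(Cc2c(Cl)cccc2Cl)n1` — 400 nM
compound 3 `O=C(Nc1ccc(C(F)(F)C(F)(F)F)cc1)c1csc(Cc2c(Cl)cccc2Cl)n1` — 290 nM

In an assay on CHO cells, read by calcium flux (on this read-out lower numbers stand for stronger inhibition and higher numbers for weaker inhibition), compound 2 stands second highest of the three numbers. Its nearest neighbour is compound 3, a 1.4-fold lower number from compound 2 to compound 3 (0.14 log units; within the scatter), and its furthest is compound 1, a 1.4-fold lower number from compound 1 to compound 2 (0.15 log units; within the scatter); both steps sit within the scatter, so the three measured compounds cannot be ranked against each other on this read-out.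

The next compound, compound 4 `O=C(Nc1cccc(Br)c1)c1csc(Cc2c(Cl)cccc2Cl)n1`, differs from compound 2 only in where the bromine sits: 3-bromophenyl in place of 4-bromophenyl on an amide-type nitrogen.

Within the data shown here, none of the measured steps bears directly on this change. The three steps seen so far, a 1.4-fold lower number from compound 1 to compound 2 (0.15 log units; within the scatter), a 2.0-fold lower number from compound 1 to compound 3 (0.29 log units; within the scatter) and a 1.4-fold lower number from compound 2 to compound 3 (0.14 log units; within the scatter), all exchange one group for another at the same position of the ring and all lie within the scatter, so they say nothing about how this assay responds to a bromine placed differently on that ring. With no guide in the data, the expectation for compound 4 is a number near that of compound 2, with a wide range on either side and no direction preferred beyond the scatter.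

For compound 4 the estimated step is a 1.5-fold higher number from compound 2 to compound 4 (0.18 log units; within the scatter).

Compound 4 is therefore expected to give about 600 nM in this assay, estimated to fall between 250 nM and 1500 nM.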

Compound 4, half-maximal inhibitory concentration: > 4000 nM
Compound 4 ended at the assay's limit; the forecaster's own chance of this, stated with the estimate: 3%; middle value at least 6.6-fold (0.82 log units) from the limit.
By their numbers in this assay, from the lowest: compounds 3, 2 and 1 (each within the scatter of the next). At a limit, above all of these: compound 4.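

Moving the bromine is the first change in the series to go beyond the scatter: 3-bromophenyl in place of 4-bromophenyl on an amide-type nitrogen gives an at least 10-fold higher number from compound 2 to compound 4 (1.00 log units; beyond the scatter), with the atoms themselves unchanged. In this assay compound 4 gives > 4000 nM, which is a limit of the assay and not a number: the limit of > 4000 nM in this assay, at which 1 of the 4 values shown sits. The exchanges among tert-butyl, bromo and 1,1,2,2,2-pentafluoroethyl all stayed within the scatter, the largest being a 2.0-fold lower number from compound 1 to compound 3 (0.29 log units; within the scatter), so placement of the bromine registers on this read-out where those exchanges did not.

Among these compounds, only this one pair speaks to placement, so it remains open whether tert-butyl or 1,1,2,2,2-pentafluoroethyl would respond to the same move as bromo does. Also open, on these data alone, is how an amine or a carboxylic acid in place of the bromine would read in this assay at either placement.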